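Swapping tert-butyl for methylsulfanyl: expected receptor potency

A few compounds are considered here, and "the series" means these few. Any claim that something is new, unique, unknown or untested is made for them only; others in the source may bear on it.

Measured compounds:
compound 1 `COC(=O)/C=C/c1cccc(N(Cc2ccc(/C=C/c3cccc(F)c3)cc2)C(=O)C(C)C)c1` gives 71 nM in an assay on isolated protein with Bile acid receptor (Homo sapiens) as the target; on this read-out lower numbers stand for an effect already at smaller amounts and higher numbers for an effect only at larger amounts of compound
compound 2 `COC(=O)/C=C/c1cccc(N(Cc2ccc(-c3ccc(OC)cc3)cc2)C(=O)C2CCCCC2)c1` gives 89 nM
compound 3 `COC(=O)/C=C/c1cccc(N(Cc2ccc(-c3ccc(C(C)(C)C)cc3)cc2)C(=O)C2CCCCC2)c1` gives 132 nM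

Compound 3 gives the highest number of the three, yet its gaps to compound 2 and to compound 1 are both within the scatter, so no order can be read among them. Compound 4 `COC(=O)/C=C/c1cccc(N(Cc2ccc(-c3ccc(SC)cc3)cc2)C(=O)C2CCCCC2)c1` differs from compound 3 by methylsulfanyl in place of tert-butyl on an aromatic carbon. Among the measured compounds shown here, the only measured step at this spot is a 1.5-fold higher number from compound 2 to compound 3 (0.17 log units; within the scatter), which shows that exchanging one group for another there barely moved the number. A similarly quiet outcome is expected for compound 4, namely a 1.3-fold lower number from compound 3 to compound 4 (0.12 log units; within the scatter). Compound 4 is therefore estimated at 100 nM, with a likely range from 50 nM to 200 nM.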

Compound 4, half-maximal effective concentration: 69 nM
Compound 4: middle estimate off by 1.4-fold (0.16 log units), on the high side; measured number inside the range.
By their numbers in this assay, from the lowest: compounds 4, 1, 2 and 3 (each within the scatter of the next).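

In this assay, a third group at this position stays within the scatter: the change from tert-butyl to methylsulfanyl gives a 1.9-fold lower number from compound 3 to compound 4 (0.28 log units; within the scatter), and the change from methoxy to methylsulfanyl gives a 1.3-fold lower number from compound 2 to compound 4 (0.11 log units; within the scatter). Methylsulfanyl has two heavy atoms against four in tert-butyl and adds a hydrogen-bond acceptor, yet the number shows no readable shift, so this position has so far tolerated all three groups. Nothing shown explains this tolerance. As far as these compounds go, it remains open whether an amine or a carboxylic acid here would stay equally quiet.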